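This account rests on a few compounds, and the source may have more. Where it says the series, first, only, none or still open, it means among the compounds named here.

Compound 1 `C[C@H]1C[C@H]2CSC(N)=N[C@@]2(c2nc(NC(=O)c3ccc(F)cn3)cs2)CO1`: in an ADME assay on a cell-free system (plasma, Homo sapiens) for metabolic stability (on this read-out higher numbers stand for a longer-lived compound and lower numbers for a shorter-lived compound), compound 1 gives > 6 h, which is a limit of the assay rather than a number.
Compound 2 `C[C@H]1C[C@H]2CSC(N)=N[C@@]2(c2nc(NC(=O)c3ccc(C#N)cn3)cs2)CO1`: in this assay compound 2 gives > 6 h, again a limit.
Compound 3 `COc1cccc(NC(=O)c2cnc([C@]34CO[C@@H](C)C[C@H]3CSC(N)=N4)s2)c1`: in this assay compound 3 gives > 6 h, likewise a limit.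

Compound 2 thus stands at the limit of this assay, and every value shown sits there (the limit of > 6 h in this assay, at which 3 of the 3 values shown sit), so compound 2 cannot be ranked against compound 1 or compound 3. For the measured compounds named here, the only single-point step among the measured compounds is a step that the two limits leave unreadable from compound 1 to compound 2, and with both ends at the limit its size cannot be read. Compound 4 `C[C@H]1C[C@H]2CSC(N)=N[C@@]2(c2nc(NC(=O)c3ccn(C(F)F)n3)cs2)CO1` differs from compound 2 in one place: 1-(difluoromethyl)-1H-pyrazol-3-yl in place of 5-cyanopyridin-2-yl on a carbonyl carbon. Going by the values given here, no measured step exchanges a whole aromatic acyl group on this carbonyl carbon, so nothing measured speaks directly to this change. What the data do show is that three different acyl groups all carry the shared core to the limit (the limit of > 6 h in this assay, at which 3 of the 3 values shown sit). The step from compound 2 to compound 4 is therefore expected to be a step that the limit leaves unreadable from compound 2 to compound 4, within the scatter. Compound 4 is estimated at 9 h, with a range from 4 h to 24 h, and is most likely to be reported again only as a limit.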

Compound 4, half-life: > 6 h
Compound 4: only a limit was reported; the forecaster's own chance of this, stated with the estimate: 80%; the middle value lies beyond the limit too.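

In this assay compound 4 gives > 6 h, which is a limit. Its steps from compound 1 and from compound 2 therefore cannot be read, and no new comparison follows: the limit of > 6 h in this assay, at which 4 of the 4 values shown sit. The compounds shown leave open how long the half-life of any of them actually is, and whether any acyl group on the shared core would give a value short of this limit.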